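A few compounds are considered here, and "the series" means these few. Any claim that something is new, unique, unknown or untested is made for them only; others in the source may bear on it.

Measured compounds in a functional assay on HCT-116 cells (Homo sapiens) for cytotoxicity, read by MTT assay, with a stated time of 72 h; on this read-out higher numbers stand for weaker inhibition and lower numbers for stronger inhibition:
- compound 1, `O=C(NCCO)c1cc2ccc(OCc3ccc([N+](=O)[O-])cc3)cc2oc1=O`, gives 33400 nM
- compound 2, `O=C(NO)c1cc2ccc(OCc3ccccc3)cc2oc1=O`, gives 39500 nM
- compound 3, `NNC(=O)c1cc2ccc(OCc3ccccc3)cc2oc1=O`, is reported only as a limit of the assay, > 100000 nM

Compound 3 thus stands at the weak end of the three values, with no number beyond the limit itself. Of the three, (the limit of > 100000 nM in this assay, at which 1 of the 3 values shown sits). Within the data shown here, the one measured step between neighbours, an at least 2.5-fold higher number from compound 2 to compound 3 (0.40 log units; beyond the scatter), concerns the amide-type nitrogen and not the aromatic ring.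

Compound 4, `NNC(=O)c1cc2ccc(OCc3ccc([N+](=O)[O-])cc3)cc2oc1=O`, differs from compound 3 by nitro in place of hydrogen on an aromatic carbon. Among the measured compounds shown here, no measured step covers this change on its own: compound 1 carries the nitro group and compound 2 does not, but the two also differ at the amide nitrogen, so their values cannot be read as a step for the nitro group. For the measured compounds named here, with no step bearing on it, no change beyond the scatter is expected in this assay.

Compound 4 is therefore estimated at 120000 nM, with a likely range from 40000 nM to 400000 nM. The expected step is a step that the limit leaves unreadable from compound 3 to compound 4, and a value reported only as a limit is considered likely.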

Compound 4, half-maximal inhibitory concentration: > 100000 nM
Compound 4: a limit, no number; the forecaster's own chance of this, stated with the estimate: 65%; the middle value lies beyond the limit too.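

In this assay, with the nitro group present on both compounds, amino in place of 2-hydroxyethyl on the amide-type nitrogen gives an at least 2.9-fold higher number from compound 1 to compound 4 (0.47 log units; beyond the scatter). This runs the same way as the earlier change of hydroxy to amino on that nitrogen without the nitro group, an at least 2.5-fold higher number from compound 2 to compound 3 (0.40 log units; beyond the scatter), so in both pairs the compound with amino has the higher number. What the nitro group itself does cannot be read, because compound 3 and compound 4 are both reported only as limits, not numbers: the limit of > 100000 nM in this assay, at which 2 of the 4 values shown sit.

The compounds shown leave open whether the nitro group changes the number when the amide-type nitrogen carries hydroxy or 2-hydroxyethyl. Also open, from the compounds shown here alone, is whether a methoxy group in place of the nitro group, or a longer chain on that nitrogen, would give a readable value.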